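A few compounds are considered here, and "the series" means these few. Any claim that something is new, unique, unknown or untested is made for them only; others in the source may bear on it.

Compound 1 `CCNCCC(=O)Nc1cccc2c1CN(C)CC2c1ccccc1` and compound 2 `CCCCNCCC(=O)Nc1cccc2c1CN(C)CC2c1ccccc1` share one core and differ in a single place. In a functional assay on the whole organism for inhibition, with Mus musculus as the target (a higher number here means that more compound is needed for the effect, a lower number that less compound is needed), compound 1 reaches only a limit of the assay, > 200 mg/kg. In this assay compound 2 gives about 46 mg/kg. The change between the two is ethyl in place of hydrogen on a saturated chain carbon, two bonds along the chain from an amine nitrogen, and it produces an at least 4.3-fold lower number from compound 1 to compound 2 (0.63 log units; beyond the scatter). The size of that step rests on a limit, namely (the limit of > 200 mg/kg in this assay, at which 1 of the 3 values shown sits), so its true extent may be larger than the number shows.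

Compound 3 `CCNCC(=O)Nc1cccc2c1CN(C)CC2c1ccc(Cl)cc1` is built on a second core; the difference between the two cores is not broken down here. In this assay compound 3 gives 24 mg/kg, which lies within the usual scatter of the value of compound 2.

Compound 4 `CCCCNCC(=O)Nc1cccc2c1CN(C)CC2c1ccc(Cl)cc1` has not yet been measured. It differs from compound 3 by ethyl in place of hydrogen on a saturated chain carbon, two bonds along the chain from an amine nitrogen, which is the same change, at the same place, as that from compound 1 to compound 2. Going by the values given here, because the step from compound 1 to compound 2 was an at least 4.3-fold lower number from compound 1 to compound 2 (0.63 log units; beyond the scatter), a step of similar direction and at least similar size is expected here, with the reservation that only one such pair is available. In this assay compound 4 is expected to give 7 mg/kg, with a likely range from 2.5 mg/kg to 20 mg/kg. This estimate corresponds to a 3.4-fold lower number from compound 3 to compound 4 (0.54 log units; beyond the scatter).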

Compound 4, dose for half-maximal effect: 13.5 mg/kg
For compound 4 the middle estimate is 1.9-fold (0.29 log units) below the measured one; low and high end bracket the measured number.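

On the core of compound 3, ethyl in place of hydrogen on a saturated chain carbon, two bonds along the chain from an amine nitrogen, turns ethylamino into butylamino and gives in this assay a 1.8-fold lower number from compound 3 to compound 4 (0.25 log units; within the scatter), so on this core the change leaves the number within the usual scatter. The two available pairs show neither that the change has the same size on both cores nor that its size depends on the core: the same change on two cores in this assay, an at least 4.3-fold lower number (0.63 log units; beyond the scatter) from compound 1 to compound 2 and a 1.8-fold lower number (0.25 log units; within the scatter) from compound 3 to compound 4; the limit leaves it open whether they differ The earlier step starts from a limit, the one reached by compound 1, and this leaves its true size unknown: the limit of > 200 mg/kg in this assay, at which 1 of the 4 values shown sits.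

Going by these compounds, with only these two pairs, it remains open how the change would behave on any further core, and how the parts of the difference between the two cores, including the chloro group on the core of compound 3, each bear on the result. On these data alone, it is also open whether a longer chain than butyl on the amine nitrogen, a branched chain such as isobutyl, or a cyclic amine such as piperidine would give a step in this assay that can be read beyond the scatter on either core.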